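Replacing the Dibromophenyl Group of Compound 3

The source may report more compounds than this note shows. Statements on the series, on what has been measured and on what is new or still open speak of the compounds shown alone.

In an ADME assay on MT4 cells (Homo sapiens) for cytotoxicity, read by MTT assay (on this read-out lower numbers stand for higher toxicity in this test and higher numbers for lower toxicity in this test), compound 3 `O=C(CSc1nncnc1-c1ccccc1Cl)c1ccc(Br)cc1Br` gives 28000 nM, the lowest of three numbers. Compound 1 `Cc1ccc(NC(=O)CSc2nncnc2-c2cccc3ccccc23)c(Br)c1` gives 166000 nM and compound 2 `COC(=O)c1ccc(NC(=O)CSc2nncnc2-c2cccc3ccccc23)c(Br)c1` gives 173000 nM. Compound 4 `O=C(CSc1nncnc1-c1ccccc1Cl)Nc1cccnc1Cl` differs from compound 3 by one change: (2-chloropyridin-3-yl)amino in place of 2,4-dibromophenyl on a carbonyl carbon, with (2-chloropyridin-3-yl)amino in place of 2,4-dibromophenyl on a carbonyl carbon. Among the measured compounds shown here, the only measured step, a 1.0-fold higher number from compound 1 to compound 2 (0.02 log units; within the scatter), is a different change, methoxycarbonyl in place of methyl on an aromatic carbon, and it stays within the scatter. Compound 2 at 173000 nM also has an amino group on its carbonyl, as does compound 1, so a rise is expected, though both differ from compound 3 elsewhere too. The estimated step is a 3.2-fold higher number from compound 3 to compound 4 (0.51 log units; beyond the scatter), upward and beyond the scatter. For compound 4 the estimated value is 90000 nM, with a range of 30000 nM to 250000 nM.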

Compound 4, half-maximal cytotoxic concentration: 167000 nM
For compound 4 the middle estimate is 1.9-fold (0.27 log units) below the measured one; low and high end bracket the measured number.
By their numbers in this assay, from the lowest: compound 3; then compounds 1, 4 and 2 (each within the scatter of the next).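

On a carbonyl carbon, putting (2-chloropyridin-3-yl)amino in place of 2,4-dibromophenyl gives a 6.0-fold higher number from compound 3 to compound 4 (0.78 log units; beyond the scatter) in this assay and so points to lower toxicity in this test. Unlike the one earlier step, this change moves the number beyond the scatter. It alters the ring, the halogens and the link to the carbonyl together, while the count of heavy atoms stays the same, and no measurement here explains the rise.

Going by these compounds, what remains open is which part carries the step. A plain phenylamino group on the same carbonyl would help separate the effect of the amino link from that of the ring.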